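The source may hold more compounds than are shown below. What is called first, only, known or untested is meant among the compounds shown, and "the series" means these compounds.

Measured compounds in a functional assay on NCI-H522 cells (Homo sapiens) for cytotoxicity, with a stated time of 3 days; on this read-out lower numbers stand for stronger inhibition and higher numbers for weaker inhibition:
- compound 1 `Ic1nc2ccccc2o1`: 11700 nM
- compound 2 `C=Cc1nc2ccccc2[se]1`: 12200 nM
- compound 3 `Brc1nc2ccccc2o1`: only a limit, > 40000 nM

Compound 3 stands at the weak end of what has been measured. In this assay compound 3 gives no number, only (the limit of > 40000 nM in this assay, at which 1 of the 3 values shown sits), so its true value could lie anywhere beyond that limit. For the measured compounds named here, the one measured step that touches compound 3 is an at least 3.4-fold higher number from compound 1 to compound 3 (0.53 log units; beyond the scatter), which shows that bromo in place of iodo on the aromatic carbon of the shared core made inhibition weaker by at least a modest amount.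

Compound 4 `C=Cc1nc2ccccc2o1` differs from compound 3 by vinyl in place of bromo on an aromatic carbon. Going by the values given here, no measured step covers this exact change, so the expectation must rest on the values shown. Compound 2 also carries a vinyl group, on a core differing only in its ring heteroatom, and in this assay compound 2 gives 12200 nM. Compound 1 gives 11700 nM, a similar number. Both sit well inside the measurable range, whereas compound 3 does not.

Compound 4 is therefore expected to return to the range of compound 1 and compound 2, an estimated step of an at least 3.3-fold lower number from compound 3 to compound 4 (0.52 log units; beyond the scatter) towards stronger inhibition. The estimate for compound 4 in this assay is 12000 nM, with a range from 4000 nM to 40000 nM.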

Compound 4, half-maximal inhibitory concentration: > 40000 nM
Compound 4 ended at the assay's limit; the forecaster's own chance of this, stated with the estimate: 20%; at least 3.3-fold (0.52 log units) between middle value and limit.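

Swapping iodo for vinyl on this aromatic carbon, next to the ring nitrogen and next to the ring oxygen, gives an at least 3.4-fold higher number from compound 1 to compound 4 (0.53 log units; beyond the scatter) in this assay, so on this core a second replacement for iodo, and not only bromo, leaves inhibition weaker. Compound 2 carries the same vinyl group on a core differing only in its ring heteroatom and gives 12200 nM, so the vinyl group alone does not decide the outcome, and a measurable value for it appears only on that other core. Compound 3 and compound 4 both end at a limit, which means the step between them cannot be read and leaves iodo as the only one of the three groups on this core with a measured value: the limit of > 40000 nM in this assay, at which 2 of the 4 values shown sit.

From the compounds shown here alone, how far beyond that limit compound 3 and compound 4 truly lie stays unknown, so either of them could be the weaker one. Going by these compounds, it also stays open whether iodo is unusual here, or whether another group on this same carbon, such as an amine or a longer carbon chain, would also give a measurable value.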